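Oxazolidinone series: acetoxy to imidazolyl at the chain carbon

The compounds below may be only part of what the source reports. "The series", "measured", "known", "first", "only" and "open" are said of these compounds alone.

Compound 3 `CC(=O)OC[C@H]1CN(c2ccc(-n3cc(-c4ccccn4)cn3)c(F)c2)C(=O)O1` is measured only in an ADME assay on HEK293-A cells (Homo sapiens) for cytotoxicity, read by MTT assay, with a stated time of 48 h; a lower number here means a stronger inhibitor, a higher number a weaker inhibitor. In this assay compound 3 gives > 400 ug/mL, which is a limit of the assay and not a number, so compound 3 stands at the top of the shown range (the limit of > 400 ug/mL in this assay, at which 2 of the 3 values shown sit). Compound 1 `CN(CCC#N)C[C@H]1CN(c2ccc(-n3cc(-c4ccccn4)cn3)c(F)c2)C(=O)O1` is at the same limit: in this assay compound 1 gives > 400 ug/mL. Compound 2 `CN1CCN(C[C@H]2CN(c3ccc(-n4cc(-c5ccccn5)cn4)c(F)c3)C(=O)O2)CC1` gives 70 ug/mL in this assay. The step from compound 3 to compound 4 `O=C1O[C@@H](Cn2ccnc2)CN1c1ccc(-n2cc(-c3ccccn3)cn2)c(F)c1` is 1H-imidazol-1-yl in place of acetoxy on a saturated chain carbon bound to a saturated ring carbon. Among the compounds with values here, the steps that bear on it are an at least 5.7-fold lower number from compound 1 to compound 2 (0.75 log units; beyond the scatter) and an at least 5.7-fold higher number from compound 2 to compound 3 (0.75 log units; beyond the scatter); the third, a step that the two limits leave unreadable from compound 1 to compound 3, shows that two limits cannot be compared. Replacing acetoxy thus moved the number down once, with 4-methylpiperazin-1-yl, and not at all readably with (2-cyanoethyl)(methyl)amino. The 1H-imidazol-1-yl of compound 4 has no measured neighbour, so only a small step, if any beyond the scatter, is expected: an at least 1.2-fold lower number from compound 3 to compound 4 (0.09 log units; that floor lies within the scatter). Compound 4 is estimated at 320 ug/mL, between 110 ug/mL and 400 ug/mL.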

Compound 4, half-maximal inhibitory concentration: > 400 ug/mL
Compound 4 gave a limit, no number; the forecaster's own chance of this, stated with the estimate: 60%; middle value at least 1.2-fold (0.09 log units) away from the limit.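

In this assay compound 4 gives > 400 ug/mL, which is a limit of the assay and not a number. On this saturated chain carbon bound to a saturated ring carbon, 1H-imidazol-1-yl, the only five-membered aromatic ring shown here, thus stands with acetoxy and (2-cyanoethyl)(methyl)amino, and the steps among compound 1, compound 3 and compound 4 cannot be read. Against 4-methylpiperazin-1-yl the change is an at least 5.7-fold higher number from compound 2 to compound 4 (0.75 log units; beyond the scatter), which leaves compound 2 as the only compound of the four with a number: the limit of > 400 ug/mL in this assay, at which 3 of the 4 values shown sit.

As far as these compounds go, whether a morpholine, a piperidine, an unsubstituted piperazine or a carboxylic acid on this carbon would give a number in this assay stays open. From the compounds shown here alone, how far compound 1, compound 3 and compound 4 lie from one another also stays open.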